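A few compounds are considered here, and "the series" means these few. Any claim that something is new, unique, unknown or untested is made for them only; others in the source may bear on it.

Measured in a functional assay on Raji cells (Homo sapiens) for antiproliferative activity, read by MTT assay, with a stated time of 48 h; on this read-out higher numbers stand for weaker inhibition and lower numbers for stronger inhibition:
- compound 1 `CN(C)CCCCn1c(N)c(-c2nc3ccccc3n2C)c2nc(C#N)c(C#N)nc21`: 320 nM
- compound 2 `CCN(CC)CCn1c(N)c(-c2nc3cc(Cl)ccc3[nH]2)c2nc(C#N)c(C#N)nc21`: 31500 nM

Compound 2 stands as the higher of these two numbers, beyond the scatter from compound 1. Compound 3 `CN(C)CCCCn1c(N)c(-c2nc3cc(Cl)ccc3[nH]2)c2nc(C#N)c(C#N)nc21` has the same atoms as compound 2, joined differently: 2-(dimethylamino)ethyl in place of diethylamino on a saturated chain carbon, two bonds along the chain from an aromatic nitrogen. Within the data shown here, no measured step isolates this change. Compound 1, which carries the 4-(dimethylamino)butyl chain on a different remainder, gives 320 nM. On that basis, stronger inhibition beyond the scatter is expected in this assay, though less than that value alone might suggest. The expected change is a 13-fold lower number from compound 2 to compound 3 (1.10 log units; beyond the scatter). For compound 3 the estimated value is 2500 nM, with an expected range of 400 nM to 15000 nM.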

Compound 3, half-maximal inhibitory concentration: 950 nM
For compound 3 the middle estimate is 2.6-fold (0.42 log units) above the measured one, and the stated range covers the measured number.
By their numbers in this assay, from the lowest: compound 1; then compound 3; then compound 2.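

In this assay, among these compounds, the 4-(dimethylamino)butyl chain in place of the 2-(diethylamino)ethyl chain on an otherwise unchanged core gives a 33-fold lower number from compound 2 to compound 3 (1.52 log units; beyond the scatter), the first reading that isolates this position. With that chain held constant, 5-chloro-1H-benzimidazol-2-yl in place of 1-methyl-1H-benzimidazol-2-yl gives a 3.0-fold higher number from compound 1 to compound 3 (0.47 log units; beyond the scatter), a smaller step than the chain change. No measurement at hand accounts for either step.

Chain length and the amine's alkyl groups change together here, so their separate contributions stay open. A 4-(diethylamino)butyl or 2-(dimethylamino)ethyl chain would separate them.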